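Replacing the aromatic group on a sulfonyl sulfur

The source may hold more compounds than are shown below. What is called first, only, known or untested is meant among the compounds shown, and "the series" means these compounds.

Measured so far in an ADME assay on HCT-116 cells (Homo sapiens) for cytotoxicity, read by CellTiter-Glo, with a stated time of 72 h; a lower number here means a stronger inhibitor, a higher number a weaker inhibitor:
Compound 1 `CC1CCN(C2CCN(S(=O)(=O)c3ccccc3Br)CC2)CC1` gives > 5000 nM as a limit
Compound 2 `CC1CCN(C2CCN(S(=O)(=O)c3cnc(Cl)s3)CC2)CC1` gives > 10000 nM as a limit
Compound 3 `Cc1ccc(S(=O)(=O)N2CCC(N3CCC(C)CC3)CC2)cc1C` gives > 5000 nM as a limit

Compound 3 stands at > 5000 nM here, which is a limit and not a number. For the measured compounds named here, none of these three compounds has yet given a true number in this assay so far.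

Compound 4 `CC1CCN(C2CCN(S(=O)(=O)c3nccn3C)CC2)CC1` has 1-methyl-1H-imidazol-2-yl in place of 3,4-dimethylphenyl on a sulfonyl sulfur, and the swap counts out as follows (1-methyl-1H-imidazol-2-yl in place of 3,4-dimethylphenyl on a sulfonyl sulfur).

Three measured steps change the group on that same sulfur (a step that the two limits leave unreadable from compound 1 to compound 2), (a step that the two limits leave unreadable from compound 1 to compound 3) and (a step that the two limits leave unreadable from compound 2 to compound 3). None of them has a readable size, so they offer no direction to carry over. The closest guide is compound 2, whose group also has a five-membered aromatic ring, and compound 2 gives > 10000 nM as a limit.

The expected step is a step that the limit leaves unreadable from compound 3 to compound 4 and no clear direction is expected from it. Compound 4 is expected to remain weak and may well be reported only as a limit. In this assay the estimate for compound 4 is 10000 nM with a range from 5000 nM to 30000 nM expected.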

Compound 4, half-maximal inhibitory concentration: > 10000 nM
Compound 4 gave a limit, no number (the forecaster's own chance of this, stated with the estimate: 90%); the middle value lies on the limit itself.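

Compound 4 gives > 10000 nM, which is a limit and not a number. For the compounds shown here, no step from compound 1, compound 2 or compound 3 to compound 4 can be read. The compounds shown leave open whether any group on the sulfonyl sulfur gives a true number in this assay, and how far these four groups differ.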